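Swapping the pendant phenyl's chloro for a methyl

A few compounds are considered here, and "the series" means these few. Any claim that something is new, unique, unknown or untested is made for them only; others in the source may bear on it.

Among the compounds with values here, compound 2 `CNC(=O)c1cc(C(=O)N[C@H]2CC[C@H](O)CC2)c([C@@H](C)c2cccc(Cl)c2)o1` gives 150 nm/s in an ADME assay for permeability (a higher number here means that the compound crosses the layer faster, a lower number that the compound crosses the layer more slowly), one of only two numbers measured so far; the other belongs to compound 1 `CNC(=O)c1cc(C(=O)N[C@H]2CC[C@H](O)CC2)c([C@@H](C)c2cccc(C)c2)o1`, which gives 85 nm/s in this assay, and the two stand within the scatter of each other. Within the data shown here, the single measured step is a 1.8-fold higher number from compound 1 to compound 2 (0.25 log units; within the scatter). Compound 3 `CNC(=O)c1cc(C(=O)N[C@H]2CC[C@H](O)CC2)c([C@@H](C)c2ccc(C)cc2)o1` has not yet been measured in this assay. It differs from compound 2 in one place: 4-methylphenyl in place of 3-chlorophenyl on a saturated chain carbon bound to an aromatic carbon and a saturated chain carbon. The measured step bears directly on this change, since it too exchanged methyl and chloro on that phenyl, and it stayed within the scatter. Compound 3 is therefore expected to sit close to compound 1, with a step of a 1.7-fold lower number from compound 2 to compound 3 (0.22 log units; within the scatter) that is expected to stay within the scatter. Compound 3 is estimated at 90 nm/s in this assay, with a range from 45 nm/s to 180 nm/s.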

Compound 3, apparent permeability in the ADME assay: 108 nm/s
Compound 3: the middle estimate sits 1.2-fold (0.08 log units) below what was measured; measured number inside the range.
By their numbers in the ADME assay, from the lowest: compounds 1, 3 and 2 (each within the scatter of the next).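

In the ADME assay, the exchange of 3-chlorophenyl for 4-methylphenyl gives a 1.4-fold lower number from compound 2 to compound 3 (0.14 log units; within the scatter), and the exchange of 3-methylphenyl for 4-methylphenyl gives a 1.3-fold higher number from compound 1 to compound 3 (0.10 log units; within the scatter), so neither exchange at this place moves the read-out beyond the scatter. Within the data shown here, in a physicochemical assay for solubility, read by HPLC, in simulated intestinal fluid, with a stated time of 16 h, at pH 6.5 (a lower number here means a less soluble compound, a higher number a more soluble compound), compound 2 gives 408 ug/mL, and the same exchange reads an at least 2.4-fold higher number from compound 2 to compound 3 (0.38 log units; beyond the scatter), the first step here that lies beyond the scatter. In the physicochemical assay compound 3 gives > 1000 ug/mL, which is a limit of the assay and not a number.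

Going by these compounds, the true size of that last step stays open: the limit of > 1000 ug/mL in the physicochemical assay, at which 1 of the 2 values shown sits. Also open is how a phenyl ring carrying an amine or a carboxylic acid at this place would read in the ADME assay and in the physicochemical assay.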